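Aryl swap on the shared core: compound 1 to compound 4

The compounds below may be only part of what the source reports. "The series", "measured", "known", "first", "only" and "open" are said of these compounds alone.

Compound 1 `c1ccc(-c2ccncc2)c(OCC2=NCCN2)c1` gives in a functional assay for activation of Alpha-1D adrenergic receptor (Homo sapiens), read by calcium flux; a lower number here means that less compound is needed, a higher number that more compound is needed for the effect < 100000 nM, a limit of the assay rather than a number.
Compound 2 `Cc1cccnc1-c1ccccc1OCC1=NCCN1` gives in this assay < 100000 nM, likewise a limit.
Compound 3 `Cc1cccc(-c2ccccc2OCC2=NCCN2)n1` gives in this assay < 100000 nM, again a limit.

Compound 1 thus stands only at an assay limit, as do the other two; (the limit of < 100000 nM in this assay, at which 3 of the 3 values shown sit). Among the compounds with values here, no step between measured compounds can be stated, and no measured step is available to lean on. Compound 4 `c1c[nH]c(-c2ccccc2OCC2=NCCN2)c1` differs from compound 1 by 1H-pyrrol-2-yl in place of pyridin-4-yl on an aromatic carbon. Without a measured step, no change beyond the scatter is expected, and the step expected is a step that the limit leaves unreadable from compound 1 to compound 4. Compound 4 is estimated at 30000 nM, with a range from 3000 nM to 100000 nM, and it is expected most likely to be reported again only as a limit.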

Compound 4, half-maximal effective concentration: 6.31 nM
Beside the measured number, compound 4's estimate is 4800-fold (3.68 log units) above it, outside the stated range (below it).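

Within the data shown here, no step from compound 1 to compound 4 can be read, since compound 1 stands only at an assay limit: the limit of < 100000 nM in this assay, at which 3 of the 4 values shown sit. The compounds shown leave open how large the gap in this assay between compound 1 and compound 4 really is.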